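The compounds below may be only part of what the source reports. "The series", "measured", "known", "first", "only" and "open" are said of these compounds alone.

Compound 1 `CCNc1ccc2c(c1)OC(N)=C(C#N)C2c1cccc([N+](=O)[O-])c1`, compound 2 `CCNc1ccc2c(c1)OC(N)=C(C#N)C2c1cccc(OC)c1` and compound 3 `COc1ccc2c(c1)OC(N)=C(C#N)C2c1cccnc1` share one core and were all tested in a functional assay on T47D cells (Homo sapiens) for activation; on this read-out lower numbers stand for an effect already at smaller amounts and higher numbers for an effect only at larger amounts of compound. In this assay compound 1 gives 110000000 nM, and compound 2 gives 110000000 nM, so the two stand level. Compound 3 gives 170000000 nM, which lies within the scatter of compound 1. Compound 4 `COc1ccc2c(c1)OC(N)=C(C#N)C2c1cccc([N+](=O)[O-])c1` has not yet been measured in this assay. It differs from compound 1 in one place: methoxy in place of ethylamino on an aromatic carbon. Going by the values given here, no measured pair shows exactly this exchange. Among the compounds with values here, the single measured step, no change at the digits printed from compound 1 to compound 2 (within the scatter), concerns a different position and shows that swapping one group for another there left the read-out unchanged. Compound 3, which already carries the methoxy of compound 4 on the core, also sits within the scatter of compound 1. Compound 4 is therefore expected to sit close to compound 1, with a step of a 1.2-fold higher number from compound 1 to compound 4 (0.07 log units; within the scatter) that stays within the scatter. The estimate for compound 4 in this assay is 130000000 nM, with a range from 60000000 nM to 300000000 nM.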

Compound 4, half-maximal effective concentration: 88900000 nM
The estimate for compound 4 lay 1.5-fold (0.17 log units) above the measured number; low and high end bracket the measured number.
By their numbers in this assay, from the lowest: compounds 4, 1, 2 and 3 (each within the scatter of the next).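

Going by these compounds alone, exchanging ethylamino for methoxy on this aromatic carbon of the shared core gives a 1.2-fold lower number from compound 1 to compound 4 (0.09 log units; within the scatter) in this assay and is the first measured exchange at this position. The read-out therefore stays within the scatter even though the entering group has one heavy atom fewer and no hydrogen-bond donor, with oxygen rather than nitrogen attached to the ring. Nothing measured here explains why the read-out holds at this position.

Still open, from the compounds shown here alone, is whether the same carbon would give a similar number with a carboxylic acid, a primary amine or a longer chain such as butoxy. Also open, going by these compounds, is whether a hydroxyl group, which is smaller than methoxy, would leave the read-out just as unchanged.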